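Bromo for methoxy in a weakly active series

The source may report more compounds than this note shows. Statements on the series, on what has been measured and on what is new or still open speak of the compounds shown alone.

compound 1 `COc1ccc(N2CCCC2)c(C(=O)Nc2ccc(CNC(=O)OCc3cccnc3)cc2)c1`: 85700 nM
compound 2 `Cc1cccc(C(=O)Nc2ccc(CNC(=O)OCc3cccnc3)cc2)c1N1CCCC1`: > 100000 nM (a limit)
compound 3 `Cc1ccc(C(=O)Nc2ccc(CNC(=O)OCc3cccnc3)cc2)c(N2CCCC2)c1`: > 100000 nM (a limit)

For the measured compounds named here, in a functional assay on MGC-803 cells (Homo sapiens) for inhibition, read by MTT assay, with a stated time of 72 h (on this read-out lower numbers stand for stronger inhibition and higher numbers for weaker inhibition), compound 1 stands at 85700 nM, the only true number among the three. The other two values are limits of the assay. Compound 4 `O=C(NCc1ccc(NC(=O)c2cc(Br)ccc2N2CCCC2)cc1)OCc1cccnc1` keeps the core of compound 1 but carries bromo in place of methoxy on an aromatic carbon, para to a pyrrolidin-1-yl group (bromo in place of methoxy on an aromatic carbon). Going by the values given here, no measured pair differs in one place only, so the expectation rests on compound 1 at 85700 nM alone. A small gain in this assay, scarcely beyond the usual scatter, is expected, an estimated 1.7-fold lower number from compound 1 to compound 4 (0.23 log units; within the scatter). Compound 4 is expected at 50000 nM, within an estimated range of 12000 nM to 100000 nM.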

Compound 4, half-maximal inhibitory concentration: 45700 nM
Beside the measured number, compound 4's estimate is 1.1-fold (0.04 log units) above it; the range from low to high includes it.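

In this assay, bromo in place of methoxy, para to a pyrrolidin-1-yl group, gives a 1.9-fold lower number from compound 1 to compound 4 (0.27 log units; within the scatter), so the two groups cannot be told apart at this position. Compound 4, like compound 1, gives a true number rather than a limit. Compound 2 and compound 3 give limits, and no step to either can be read: the limit of > 100000 nM in this assay, at which 2 of the 4 values shown sit.

From the compounds shown here alone, whether an amine or a carboxylic acid on this aromatic carbon would give a step beyond the scatter stays open.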